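Swapping the Amide-Side Aryl Group for a Sulfonamide-Bearing Ring

The source may report more compounds than this note shows. Statements on the series, on what has been measured and on what is new or still open speak of the compounds shown alone.

Compound 1 `COc1ccc(CNC(=O)c2nc(-c3ccc(F)cc3)n(CC[C@@H](O)C[C@@H](O)CC(=O)O)c2C2CC2)cc1` and compound 2 `O=C(O)C[C@H](O)C[C@H](O)CCn1c(-c2ccc(F)cc2)nc(C(=O)NCc2ccc(F)c(F)c2)c1C1CC1` share one core and differ only in the aromatic ring that sits on the saturated chain carbon bound to the amide-type nitrogen. In a functional assay on cells (Hepatocyte, Rattus norvegicus) for inhibition, read by scintillation counting, with a stated time of 4 h (on this read-out higher numbers stand for weaker inhibition and lower numbers for stronger inhibition), compound 1 gives 0.2 nM, while compound 2 gives 0.5 nM. Going by the values given here, compound 2 thus holds the higher of the two numbers, its only neighbour being compound 1, which is separated from it by a 2.5-fold higher number from compound 1 to compound 2 (0.40 log units; beyond the scatter).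

Compound 3 `CN(C)S(=O)(=O)c1ccc(CNC(=O)c2nc(-c3ccc(F)cc3)n(CC[C@@H](O)C[C@@H](O)CC(=O)O)c2C2CC2)cc1` takes the next step from compound 2: 4-(dimethylsulfamoyl)phenyl in place of 3,4-difluorophenyl on a saturated chain carbon bound to an amide-type nitrogen. Among the compounds with values here, only one measured step bears on a change at this position, the exchange of one aromatic ring for another between compound 1 and compound 2, and that step was modest. The new group brings in more atoms than the earlier exchange did, so the range must be set wide, but nothing measured here points to a large shift in either direction. The step expected is a 1.2-fold higher number from compound 2 to compound 3 (0.08 log units; within the scatter), essentially within the scatter. Compound 3 is therefore estimated at 0.6 nM, with a plausible range from 0.15 nM to 2.5 nM.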

Compound 3, half-maximal inhibitory concentration: 0.5 nM
Compound 3: middle estimate off by 1.2-fold (0.08 log units), on the high side; measured number inside the range.
By their numbers in this assay, from the lowest: compound 1; then compounds 2 and 3 (each within the scatter of the next).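

Exchanging 3,4-difluorophenyl for 4-(dimethylsulfamoyl)phenyl on a saturated chain carbon bound to an amide-type nitrogen gives no change at the digits printed from compound 2 to compound 3 (within the scatter) in this assay even though the entering group has 12 heavy atoms against 8 and brings 2 hydrogen-bond acceptors where the leaving group has 0. Seen from the other side, dimethylsulfamoyl in place of methoxy on an aromatic carbon gives a 2.5-fold higher number from compound 1 to compound 3 (0.40 log units; beyond the scatter) and this is a modest step of the same size as a 2.5-fold higher number from compound 1 to compound 2 (0.40 log units; beyond the scatter) so the two rings carrying quite different substituents land together, with only the 4-methoxyphenyl ring of compound 1 standing apart. This position therefore accepts a much larger group on the aromatic ring without the number moving further than the earlier exchange had already moved it.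

Still open, on these data alone, is whether an aromatic ring is needed here at all, which a cyclohexyl group would test, and how a pyridine ring or a carboxylic acid on the ring would read out. Nothing available explains why the three numbers fall as they do.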